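Bromo for trifluoromethyl on the sulfonamide aryl ring

The compounds below may be only part of what the source reports. "The series", "measured", "known", "first", "only" and "open" are said of these compounds alone.

Measured compounds:
- compound 1 `COc1ccc(Br)cc1S(=O)(=O)Nc1cncc(C(N)=O)c1`: 121 nM
- compound 2 `COc1ccc(C(F)(F)F)cc1S(=O)(=O)Nc1cccnc1`: 3010 nM

In an assay on isolated protein for inhibition of alkaline phosphatase, tissue-nonspecific isozyme (Homo sapiens) (on this read-out higher numbers stand for weaker inhibition and lower numbers for stronger inhibition), compound 2 gives 3010 nM, the highest of the two numbers; compound 1 gives 121 nM, a gap beyond the scatter, but the two differ in more than one place, so no single change is isolated. Compound 3 `COc1ccc(Br)cc1S(=O)(=O)Nc1cccnc1` carries bromo in place of trifluoromethyl on an aromatic carbon. Within the data shown here, no measured pair shows this change alone. Compound 1, which also carries bromo, gives 121 nM, which argues for a lower number; the step of a 3.0-fold lower number from compound 2 to compound 3 (0.48 log units; beyond the scatter) is expected as a moderate fall. Compound 3 is estimated at 1000 nM, within 300 nM to 4000 nM.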

Compound 3, half-maximal inhibitory concentration: 543 nM
Beside the measured number, compound 3's estimate is 1.8-fold (0.27 log units) above it; low and high end bracket the measured number.
By their numbers in this assay, from the lowest: compound 1; then compound 3; then compound 2.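

In this assay, the place para to a methoxy group now has an isolated change: bromo in place of trifluoromethyl gives a 5.5-fold lower number from compound 2 to compound 3 (0.74 log units; beyond the scatter) on the shared core. Hydrogen in place of carbamoyl gives a 4.5-fold higher number from compound 1 to compound 3 (0.65 log units; beyond the scatter) and so isolates a second place that bears on the number, with carbamoyl on the lower side. No measurement on hand accounts for either step. Still open, on these data alone, is how chloro, methyl or a nitrile would compare with bromo at the first place. As far as these compounds go, whether a carboxylic acid or an amine could stand in for carbamoyl also remains open.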